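Swapping Sulfamoyl for Phenyl on a Weak Inhibitor

A few compounds are considered here, and "the series" means these few. Any claim that something is new, unique, unknown or untested is made for them only; others in the source may bear on it.

Among the compounds with values here, compound 1 `NS(=O)(=O)N1CCC(C(=O)/C(=N/O)Nc2ccc(F)c(Br)c2)CC1` is the only member of this small set with a definite number: in an assay for inhibition of Tryptophan 2,3-dioxygenase (Homo sapiens), with a stated time of 1 h (a lower number here means a stronger inhibitor, a higher number a weaker inhibitor), compound 1 gives 62500 nM, a weak result. Compound 2 `O=C(/C(=N/O)Nc1ccc(F)c(Br)c1)C1CCN(S(=O)(=O)NCc2ccccc2)CC1` reaches only the assay limit, > 100000 nM. The step of an at least 1.6-fold higher number from compound 1 to compound 2 (0.20 log units; that floor lies within the scatter) is therefore only a floor, and the limit of > 100000 nM in this assay, at which 1 of the 2 values shown sits, marks where compound 2 sits. Compound 3 `O=C(/C(=N/O)Nc1ccc(F)c(Br)c1)C1CCN(c2ccccc2)CC1` differs from compound 1 by phenyl in place of sulfamoyl on an amine nitrogen in a ring. No measured step replaces the sulfamoyl group itself; the one step shown, from compound 1 to compound 2, added a benzyl group at a different place and did not make the number smaller. For compound 3 the expectation is therefore a change of a 1.3-fold higher number from compound 1 to compound 3 (0.11 log units; within the scatter), with a real chance that only a limit is seen. The estimate for compound 3 is 80000 nM, between 25000 nM and 250000 nM.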

Compound 3, half-maximal inhibitory concentration: > 100000 nM
Compound 3 was reported as a limit; the forecaster's own chance of this, stated with the estimate: 40%; middle value at least 1.2-fold (0.09 log units) from the limit.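

Putting phenyl in place of sulfamoyl on the amine nitrogen in the ring gives an at least 1.6-fold higher number from compound 1 to compound 3 (0.20 log units; that floor lies within the scatter) in this assay, so this step is only a floor and its true size cannot be read. Compound 3 gives > 100000 nM, which is a limit of the assay and not a number. The sulfamoyl group has now been replaced as a whole, not only extended on its own nitrogen, and again no smaller number appears, with most of the set now resting on the same ceiling: the limit of > 100000 nM in this assay, at which 2 of the 3 values shown sit.

The compounds shown leave open how far compound 2 and compound 3 lie past that limit, and whether any group on this ring nitrogen can give a clearly smaller number than compound 1. A free amine, a methyl group or a carboxylic acid at this place would begin to answer that.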